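Amide Aryl Swap on a Shared Cytotoxic Core

The source may report more compounds than this note shows. Statements on the series, on what has been measured and on what is new or still open speak of the compounds shown alone.

Compound 1 `C=C(CC)C(=O)c1ccc(OCC(=O)Nc2ccc(C(=O)OC)cc2)c(Cl)c1Cl`: 4100 nM
Compound 2 `C=C(CC)C(=O)c1ccc(OCC(=O)Nc2ccc3nc[nH]c3c2)c(Cl)c1Cl`: 3200 nM
Compound 3 `C=C(CC)C(=O)c1ccc(OCC(=O)Nc2ccc(O)c(Cl)c2)c(Cl)c1Cl`: 5500 nM

In a functional assay on CLL cells (Homo sapiens) for cytotoxicity, read by MTT assay, with a stated time of 48 h (on this read-out lower numbers stand for an effect already at smaller amounts and higher numbers for an effect only at larger amounts of compound), compound 1 gives 4100 nM, compound 2 gives 3200 nM and compound 3 gives 5500 nM. The number for compound 3 is the highest of the three, yet its gaps to compound 1 and to compound 2 both sit within the scatter, so the three compounds cannot be told apart on this read-out. For the measured compounds named here, the one step between neighbours that differ in a single place is a 1.7-fold higher number from compound 2 to compound 3 (0.24 log units; within the scatter), which is itself within the scatter.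

Compound 4 `C=C(CC)C(=O)c1ccc(OCC(=O)Nc2ccc(C(C)=O)cc2)c(Cl)c1Cl` is not yet measured. It differs from compound 3 as follows: 4-acetylphenyl in place of 3-chloro-4-hydroxyphenyl on an amide-type nitrogen. Going by the values given here, no measured step follows this particular change. Compound 1, which also carries a group with a carbonyl on the ring attached to the amide-type nitrogen, gives 4100 nM, and compound 3 gives 5500 nM, two values within the scatter of each other. Since every gap seen so far lies within the scatter, no step beyond the scatter is expected for compound 4 in this assay, and a 1.2-fold lower number from compound 3 to compound 4 (0.09 log units; within the scatter) is the expected outcome. Compound 4 is therefore estimated at 4500 nM, with a range from 2200 nM to 9000 nM.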

Compound 4, half-maximal effective concentration: 3900 nM
For compound 4 the middle estimate is 1.2-fold (0.06 log units) above the measured one, and the stated range covers the measured number.
By their numbers in this assay, from the lowest: compounds 2, 4, 1 and 3 (each within the scatter of the next).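

In this assay, the position on the amide-type nitrogen now tolerates a further swap: a 1.4-fold lower number from compound 3 to compound 4 (0.15 log units; within the scatter) and a 1.2-fold higher number from compound 2 to compound 4 (0.09 log units; within the scatter) both stay within the scatter, even though 4-acetylphenyl carries no hydrogen-bond donor and no chlorine, whereas 3-chloro-4-hydroxyphenyl carries one of each. The closest edit in the set, methyl in place of methoxy on a carbonyl carbon, gives a 1.1-fold lower number from compound 1 to compound 4 (0.02 log units; within the scatter), so this small change at the end of the carbonyl group also produces no step that can be told from the scatter, and no aryl group shown on this nitrogen stands apart from the others. Nothing available explains this flat picture, and no independent measurement bears on it.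

From the compounds shown here alone, it remains open whether an amine or a carboxylic acid on the ring attached to the amide-type nitrogen, or a longer chain in place of the methyl on the carbonyl carbon, would give a step beyond the scatter. All the compounds shown share one core, so they also leave open how far the read-out depends on that core rather than on the amide aryl group.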